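This account rests on a few compounds, and the source may have more. Where it says the series, first, only, none or still open, it means among the compounds named here.

Compound 3 `Cc1ccc(C(=O)NNC(=O)Cn2c(=O)c(Cc3ccccc3)nc3ccccc32)cc1` was examined in an assay for inhibition of Amine oxidase [flavin-containing] B (Bos taurus), read by fluorescence, with a stated time of 60 min (a lower number here means a stronger inhibitor, a higher number a weaker inhibitor), where compound 3 gives 680000 nM. Two other compounds built on a related framework were measured alongside it. In this assay compound 1 `O=C(NNc1nc2ccccc2nc1Cc1ccccc1)c1ccc(Cl)cc1` gives 730000 nM, and compound 2 `O=C(NNc1nc2ccccc2nc1Cc1ccccc1)c1ccc(Br)cc1` gives 980000 nM. The number for compound 3 differs from that of compound 1 and from that of compound 2 by less than the usual scatter of repeated measurements, so the three values cannot be separated from one another. Among the measured compounds shown here, the only step measured between two compounds differing in a single place is a 1.3-fold higher number from compound 1 to compound 2 (0.13 log units; within the scatter), and that step concerns a substituent on an aromatic carbon, not the part of the molecule that is altered next.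

Compound 4 `C/C(=N\NC(=O)Cn1c(=O)c(Cc2ccccc2)nc2ccccc21)c1ccc(O)cc1` is an isomer of compound 3: a group of 10 heavy atoms (8 carbon, 1 nitrogen, 1 oxygen; one six-membered aromatic ring of carbon only) in place of a group of 10 heavy atoms (8 carbon, 1 nitrogen, 1 oxygen; one six-membered aromatic ring of carbon only), on an amide-type nitrogen. For the measured compounds named here, no measured step bears on this rearrangement, and the one step available sits elsewhere and stays within the scatter. With no guidance on direction and with all three measured numbers clustered closely, no step beyond the scatter is expected, and the estimated step is a 1.0-fold higher number from compound 3 to compound 4 (0.01 log units; within the scatter). Compound 4 is therefore expected to give about 700000 nM in this assay, within a range of 250000 nM to 2000000 nM.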

Compound 4, half-maximal inhibitory concentration: 980000 nM
The estimate for compound 4 lay 1.4-fold (0.15 log units) below the measured number; low and high end bracket the measured number.
By their numbers in this assay, from the lowest: compounds 3, 1, 2 and 4 (each within the scatter of the next).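

The exchange on the amide-type nitrogen, whose other neighbour is the carbonyl carbon, gives a 1.4-fold higher number from compound 3 to compound 4 (0.16 log units; within the scatter) in this assay. This is the first step shown at this place, and it stays within the scatter, so no difference can be claimed between the ((4-methylphenyl)carbonyl)amino group and the group that enters, even though the two are joined differently and the entering group has 2 hydrogen-bond acceptors against 1. No measurement available here accounts for this result.

The compounds shown leave open whether any group at this place can give a step beyond the scatter, since both groups compared here have the same heavy atoms and the same six-membered aromatic ring of carbon only. A group of a different kind on this nitrogen, such as one ending in a carboxylic acid or an amine, or one with a longer chain before the aromatic ring, would show whether the number in this assay can be moved from this position at all.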